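Amino-Acid Esters Compared for Half-Life in Breast Cancer Cells

This account rests on a few compounds, and the source may have more. Where it says the series, first, only, none or still open, it means among the compounds named here.

Compound 1, `N[C@@H](CC(=O)OC[C@H]1O[C@@H](n2cc(F)c(=O)[nH]c2=O)C[C@@H]1O)C(=O)O`: 0.185 h
Compound 2, `N[C@@H](CCC(=O)O[C@H]1C[C@H](n2cc(F)c(=O)[nH]c2=O)O[C@@H]1CO)C(=O)O`: 0.138 h

In an ADME assay on tissue (MDA-MB-231 cells, Homo sapiens) for pharmacokinetics (a higher number here means that the compound lasts longer, a lower number that the compound disappears faster), compound 2 gives the smaller of the two numbers, yet its gap to compound 1 lies within the scatter, so neither compound can be called longer-lived than the other. Compound 3, `CC(C)[C@H](N)C(=O)O[C@H]1C[C@H](n2cc(F)c(=O)[nH]c2=O)O[C@@H]1CO`, differs from compound 2 in one place: 1-amino-2-methylpropyl in place of 3-amino-3-carboxypropyl on a carbonyl carbon. Among the compounds with values here, no pair of measured compounds shows this change, so nothing measured points either way. With the two measured values so close, no step beyond the scatter is expected from compound 2 to compound 3 in this assay, the expected step being a 1.2-fold higher number from compound 2 to compound 3 (0.06 log units; within the scatter). Compound 3 is estimated at 0.16 h, within 0.07 h to 0.4 h.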

Compound 3, half-life: 0.248 h
Compound 3: the middle estimate sits 1.6-fold (0.19 log units) below what was measured; the measured number falls inside the stated range.
By their numbers in this assay, from the lowest: compounds 2, 1 and 3 (each within the scatter of the next).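

In this assay, within the data shown here, the one step read at this position gives a 1.8-fold higher number from compound 2 to compound 3 (0.25 log units; within the scatter) for 1-amino-2-methylpropyl in place of 3-amino-3-carboxypropyl on a carbonyl carbon. So a group without a carboxy group, and with fewer heavy atoms, leaves the half-life within the scatter of the parent chain. No measurement on hand gives a reason for this result.

Still open, going by these compounds, is whether a plain isopropyl group, with no amine, would shift the half-life beyond the scatter. The same question stands for a longer chain on this carbonyl carbon.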